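A new side group on the shared core

This account rests on a few compounds, and the source may have more. Where it says the series, first, only, none or still open, it means among the compounds named here.

Of the compounds shown here, two with a shared core have been measured so far. Compound 1 `CNC(=N)Nc1nc(-c2ccc(OC)cc2)c(-c2ccc(OC)cc2)s1` gives 62 nM in a functional assay with Oryctolagus cuniculus as the target; a lower number here means a stronger inhibitor, a higher number a weaker inhibitor. Compound 2 `COc1ccc(-c2nc(/N=C(\N)NC(C)C)sc2-c2ccc(OC)cc2)cc1` reaches only the limit of > 100 nM in this assay, so no number stands for it. For the measured compounds named here, the single measured step, an at least 1.6-fold higher number from compound 1 to compound 2 (0.20 log units; that floor lies within the scatter), therefore rests on the limit of > 100 nM in this assay, at which 1 of the 2 values shown sits, and tells only that compound 2 is not stronger than compound 1.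

Compound 3 `COc1ccc(-c2nc(CNC(=O)c3cccnc3)sc2-c2ccc(OC)cc2)cc1` has not yet been measured. It differs from compound 2 by a group of 10 heavy atoms (7 carbon, 2 nitrogen, 1 oxygen; one six-membered aromatic ring with 1 hetero atom) in place of a group of 7 heavy atoms (4 carbon, 3 nitrogen; no ring), on an aromatic carbon. Going by the values given here, no measured step covers a change of this kind: the step of an at least 1.6-fold higher number from compound 1 to compound 2 (0.20 log units; that floor lies within the scatter) swaps one chain for a somewhat longer chain of the same elements, whereas compound 3 brings in a group with a six-membered aromatic ring where compound 2 carries a chain without a ring. With compound 2 standing at a limit, the direction of a step that the limit leaves unreadable from compound 2 to compound 3 is expected to be uncertain, and a wide range is estimated. Compound 3 is expected to give about 300 nM in this assay, within 60 nM to 2000 nM, with a fair chance that only a limit is reported again.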

Compound 3, half-maximal inhibitory concentration: 25 nM
Compound 3: middle estimate off by 12-fold (1.08 log units), on the high side, and the stated range ends above it.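

With the (((pyridin-3-yl)carbonyl)amino)methyl group on this aromatic carbon, next to the ring nitrogen and next to the ring sulfur, this assay gives a 2.5-fold lower number from compound 1 to compound 3 (0.39 log units; beyond the scatter), so a low number at this position does not depend on a chain without a ring. Measured against the group of compound 2, the same change reads an at least 4.0-fold lower number from compound 2 to compound 3 (0.60 log units; beyond the scatter), which is a floor and not the full size of the step. That floor stands on a limit, not a number, for compound 2: the limit of > 100 nM in this assay, at which 1 of the 3 values shown sits.

The entering group brings its methyl linker, its carbonyl, the amide hydrogen and its pyridin-3-yl ring in one change, so the compounds shown leave open which of these parts goes with the lower number. From the compounds shown here alone, it also remains open whether a phenyl ring in place of the pyridin-3-yl ring, or a longer chain between the carbonyl and the aromatic carbon, would keep the number as low, and whether the same holds with anything other than the two 4-methoxyphenyl groups on the shared core.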